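The source may hold more compounds than are shown below. What is called first, only, known or untested is meant among the compounds shown, and "the series" means these compounds.

Of the compounds shown here, two have so far been measured in an assay on HEK293 cells for inhibition of acid ceramidase (Homo sapiens), read by fluorescence, with stated times of 10 min and 3 h; on this read-out higher numbers stand for weaker inhibition and lower numbers for stronger inhibition. Compound 1, `CC(C)N1CCC(c2ccc3c(c2)oc(=O)n3C(=O)NCCCCc2ccccc2)CC1`, gives 94 nM in this assay. Compound 2, `CCC(C)NC(=O)n1c(=O)oc2cc(C3CCN(C)CC3)ccc21`, gives 2100 nM in this assay, which is the higher of the two numbers, and its gap to compound 1 lies beyond the usual scatter of repeated measurements. Compound 3, `CCCCCNC(=O)n1c(=O)oc2cc(C3CCN(C)CC3)ccc21`, has not yet been measured. It differs from compound 2 in a single place: pentyl in place of sec-butyl on an amide-type nitrogen. Within the data shown here, no step between measured compounds bears on such an exchange, so the expectation rests on compound 2 alone and carries little weight. A modest step toward a lower number is expected, a 3.0-fold lower number from compound 2 to compound 3 (0.48 log units; beyond the scatter) in this assay, though an outcome within the scatter would not be surprising. Compound 3 is therefore estimated at 700 nM in this assay, within a range from 200 nM to 3000 nM.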

Compound 3, half-maximal inhibitory concentration: 396 nM
For compound 3 the middle estimate is 1.8-fold (0.25 log units) above the measured one; the range from low to high includes it.
By their numbers in this assay, from the lowest: compound 1; then compound 3; then compound 2.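

In this assay, the group on this amide-type nitrogen proves able to shift the number on its own: pentyl in place of sec-butyl gives a clear change (a 5.3-fold lower number from compound 2 to compound 3 (0.72 log units; beyond the scatter)), and this step lies beyond the scatter. Compounds 1 and 2 differ in more than one place and could not isolate this position, whereas compound 2 and compound 3 differ only here. The exchange adds one carbon and leaves the counts of rings, hydrogen-bond donors, hydrogen-bond acceptors and net charge unchanged, but no accompanying measurement accounts for the step.

Among these compounds, the single step changes both the carbon count and the shape of the chain, so an unbranched butyl group would be needed to tell these apart. From the compounds shown here alone, whether hexyl, octyl or a cyclohexyl ring would lower the number further remains open.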